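Para-substituent changes on the benzylidene oxindole series

This account rests on a few compounds, and the source may have more. Where it says the series, first, only, none or still open, it means among the compounds named here.

- compound 1 `O=C1/C(=C\c2ccc(O)cc2)c2ccccc2N1c1c(Cl)cccc1Cl`: 2 ug/mL
- compound 2 `O=C1/C(=C\c2ccc(F)cc2)c2ccccc2N1c1c(Cl)cccc1Cl`: 5 ug/mL

In a functional assay on MIA PaCa-2 cells (Homo sapiens) for cytotoxicity, read by MTT assay, with a stated time of 72 h (on this read-out higher numbers stand for an effect only at larger amounts of compound and lower numbers for an effect already at smaller amounts), compound 1 gives 2 ug/mL, and compound 2 gives 5 ug/mL. Within the data shown here, compound 2 thus stands with the higher of the two numbers so far, and the only recorded step in this assay, a 2.5-fold higher number from compound 1 to compound 2 (0.40 log units; beyond the scatter), is the change from hydroxy to fluoro on the aromatic carbon.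

Compound 3 `COc1ccc(/C=C2\C(=O)N(c3c(Cl)cccc3Cl)c3ccccc32)cc1` is not yet measured. It differs from compound 2 as follows: methoxy in place of fluoro on an aromatic carbon.

Among the measured compounds shown here, no step with methoxy exists in this set, so only the hydroxy-to-fluoro step bears on the question. That step moved the number up modestly; methoxy, like hydroxy, brings one hydrogen-bond acceptor at this position, whereas fluoro brought none. A number for compound 3 somewhere between the two recorded values is therefore expected, with a small downward step from compound 2, a 1.3-fold lower number from compound 2 to compound 3 (0.10 log units; within the scatter), inside or close to the scatter. For compound 3 the estimate in this assay is 4 ug/mL, with a range from 1.5 ug/mL to 10 ug/mL.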

Compound 3, concentration for half-maximal effect: > 100 ug/mL
Compound 3 ended at the assay's limit; the forecaster's own chance of this, stated with the estimate: 5%; at least 25-fold (1.39 log units) between middle value and limit.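

In this assay compound 3 gives > 100 ug/mL, which is a limit of the assay and not a number, so the steps to it have a lower bound only: the limit of > 100 ug/mL in this assay, at which 1 of the 3 values shown sits.

Even so, the substituent on this aromatic carbon, para to a large group, matters far more than the first pair indicated, with an at least 20-fold higher number from compound 2 to compound 3 (1.30 log units; beyond the scatter) against only a 2.5-fold higher number from compound 1 to compound 2 (0.40 log units; beyond the scatter). Methyl in place of hydrogen on the oxygen on the aromatic ring gives an at least 50-fold higher number from compound 1 to compound 3 (1.69 log units; beyond the scatter), so an oxygen at this place is not enough by itself to keep the effect.

The compounds shown leave open whether this sharp change belongs to methoxy in particular or extends to other groups on oxygen, which an ethoxy group would test, while a methyl bonded directly to the ring or an amine at the same place would show whether the oxygen is needed at all. Also open, going by these compounds, is the size of the step to compound 3 and whether the same order of the three groups holds when the rest of the shared core is changed.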